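The source may hold more compounds than are shown below. What is called first, only, known or untested is meant among the compounds shown, and "the series" means these compounds.

Three measured compounds share one core and differ only in the group attached to an aromatic carbon at one end. Compound 1, `CN(Cc1ccc2nccn2c1)c1nnc(-c2ccc(C3CC3)cc2)o1`, carries a cyclopropyl there; compound 2, `CN(Cc1ccc2nccn2c1)c1nnc(-c2ccc(-c3ccccc3)cc2)o1`, a phenyl; compound 3, `CN(Cc1ccc2nccn2c1)c1nnc(-c2ccc(-c3ccccc3F)cc2)o1`, a 2-fluorophenyl. In an assay on isolated protein for inhibition of tyrosine-protein kinase Mer (Homo sapiens), read by LC-MS (on this read-out higher numbers stand for weaker inhibition and lower numbers for stronger inhibition), compound 1 gives 794 nM, compound 2 gives 39.8 nM, and compound 3 gives 15.9 nM. The steps of a 20-fold lower number from compound 1 to compound 2 (1.30 log units; beyond the scatter) and a 50-fold lower number from compound 1 to compound 3 (1.70 log units; beyond the scatter) are both large and well beyond the scatter, while the step of a 2.5-fold lower number from compound 2 to compound 3 (0.40 log units; beyond the scatter) is modest but still beyond it. Compound 3 therefore stands lowest of the three numbers, separated from both others by more than the scatter.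

Compound 4, `COc1ccccc1-c1ccc(-c2nnc(N(C)Cc3ccc4nccn4c3)o2)cc1`, differs from compound 3 in one place: methoxy in place of fluoro on an aromatic carbon. For the measured compounds named here, no measured pair compares methoxy with fluoro, so the closest guide is a 2.5-fold lower number from compound 2 to compound 3 (0.40 log units; beyond the scatter), which shows that a small change at this aromatic carbon moved the number only modestly. A step of similar or smaller size is expected here, in either direction, with the number most likely staying close to that of compound 3. For compound 4 the expected value in this assay is 25 nM, within a range from 8 nM to 80 nM, corresponding to an expected step of a 1.6-fold higher number from compound 3 to compound 4 (0.20 log units; within the scatter).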

Compound 4, half-maximal inhibitory concentration: 31.6 nM
The estimate for compound 4 lay 1.3-fold (0.10 log units) below the measured number, and the stated range covers the measured number.
By their numbers in this assay, from the lowest: compounds 3, 4 and 2 (each within the scatter of the next, the first and the last beyond it); then compound 1.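

In this assay, the methoxy group, with 2 heavy atoms and a hydrogen-bond acceptor, sits on the aromatic carbon ortho to a large group and gives a 2.0-fold higher number from compound 3 to compound 4 (0.30 log units; within the scatter) against fluoro and a 1.3-fold lower number from compound 2 to compound 4 (0.10 log units; within the scatter) against hydrogen, so neither change can be told apart from the scatter of repeated measurements. For the compounds shown here, the position therefore takes hydrogen, fluoro or methoxy with compound 4 staying close to both neighbours, and only the pair of compound 2 and compound 3 shows a difference beyond the scatter. The change from cyclopropyl to 2-methoxyphenyl gives a 25-fold lower number from compound 1 to compound 4 (1.40 log units; beyond the scatter) in this assay and joins the phenyl and 2-fluorophenyl compounds in lying far from compound 1, while no measurement here explains why any of these groups gives the number it does.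

From the compounds shown here alone, whether a longer chain such as ethoxy, an amine such as dimethylamino or a carboxylic acid in this same place would keep the number near these values or move it clearly away stays open. Also open, going by these compounds, is whether methoxy would behave the same way on other carbons of that ring.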